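From compound 1 to its nitro counterpart, compound 4

The source may hold more compounds than are shown below. What is called first, only, known or untested is meant among the compounds shown, and "the series" means these compounds.

- compound 1 (`COc1cc(OC)c(OC)cc1/C=C/C(=O)c1ccc(Cl)cc1`) gives 2.01 ug/mL
- compound 2 (`COc1cc(OC)c(OC)cc1/C=C/C(=O)c1ccccc1`) gives 2.01 ug/mL
- compound 3 (`COc1cc(OC)c(OC)cc1/C=C/C(=O)c1ccc(C)cc1`) gives 2.18 ug/mL

In a functional assay, read by Griess assay, with a stated time of 2.5 h (on this read-out higher numbers stand for weaker inhibition and lower numbers for stronger inhibition), compound 1 gives 2.01 ug/mL and stands level with compound 2 at the digits shown, while compound 3 lies within the scatter of both. Compound 4 (`COc1cc(OC)c(OC)cc1/C=C/C(=O)c1ccc(Cl)c([N+](=O)[O-])c1`) differs from compound 1 by one change (nitro in place of hydrogen on an aromatic carbon), with the nitro group ortho to a chloro group. The measured steps bear on this only indirectly, since they exchange chloro, hydrogen and methyl on an aromatic carbon and none introduces a nitro group. They are no change at the digits printed from compound 1 to compound 2 (within the scatter) and a 1.1-fold higher number from compound 1 to compound 3 (0.04 log units; within the scatter) and a 1.1-fold higher number from compound 2 to compound 3 (0.04 log units; within the scatter) and all stay within the scatter. These flat steps give no direction, so no change beyond the scatter is expected. The expected step is a 1.1-fold lower number from compound 1 to compound 4 (0.02 log units; within the scatter) and this estimate remains uncertain without a measured nitro compound. The value expected for compound 4 is 1.9 ug/mL with an estimated range from 0.8 ug/mL to 4.5 ug/mL around it.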

Compound 4, half-maximal inhibitory concentration: 1.99 ug/mL
For compound 4 the middle estimate is 1.0-fold (0.02 log units) below the measured one; low and high end bracket the measured number.
By their numbers in this assay, from the lowest: compounds 4, 1, 2 and 3 (each within the scatter of the next).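

Among these compounds, the step gives the first reading at a place on the aromatic ring other than the one that carries chloro, hydrogen or methyl in compounds 1, 2 and 3: in this assay, nitro in place of hydrogen, ortho to a chloro group, gives a 1.0-fold lower number from compound 1 to compound 4 (0.00 log units; within the scatter). Among the compounds shown here, this position therefore takes a group of 3 heavy atoms, larger than any group exchanged among the earlier compounds, without a shift beyond the scatter. Nothing available explains why the number holds at this position.

From the compounds shown here alone, whether an amine or a carboxylic acid at this same position would also stay within the scatter remains open. Going by these compounds, it is equally open whether a nitro group here would read the same with hydrogen or methyl in place of the chloro group.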